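A Fluorine on the Phenyl of a Compound Whose Inhibition Is Lower

A few compounds are considered here, and "the series" means these few. Any claim that something is new, unique, unknown or untested is made for them only; others in the source may bear on it.

Measured compounds:
compound 1, `CC1CCN(c2c(S(=O)(=O)c3ccccc3)cnc3ccccc23)CC1`, 89.2%
compound 2, `CC1CCN(c2c(S(=O)(=O)c3ccccc3)cnc3c(F)cccc23)CC1`, 13%
compound 3, `Cc1ccc(S(=O)(=O)c2cnc3cc(Cl)ccc3c2N2CCC(C)CC2)cc1`, 94%

Compound 2 stands lowest of the three numbers in an assay on isolated protein for displacement of a labelled ligand from metabotropic glutamate receptor 5 (Homo sapiens), with a stated time of 60 min, tested at 1 uM (on this read-out higher numbers stand for more inhibition at the one concentration tested (going by the name of the read-out) and lower numbers for less inhibition), far beneath compound 1 and compound 3, and both gaps lie beyond the scatter. For the measured compounds named here, the only single-place step recorded is a number 76.2 percentage points lower from compound 1 to compound 2 (beyond the scatter), which concerns a fluoro on the core, not the phenyl.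

Compound 4 is `CC1CCN(c2c(S(=O)(=O)c3ccc(F)cc3)cnc3c(F)cccc23)CC1`. It differs from compound 2 by fluoro in place of hydrogen on an aromatic carbon. Going by the values given here, no measured step covers this change: the step from compound 1 to compound 2 sits elsewhere, and compound 3, which carries a methyl at the same place on the phenyl, also differs from compound 2 in its core substituent, so it does not isolate the phenyl change. With no direct guide, the expectation is a step in this assay that stays within the scatter, a number 7 percentage points higher from compound 2 to compound 4 (within the scatter), leaving compound 4 low.

Compound 4 is therefore estimated at 20%, within a range from 0% to 50%.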

Compound 4, a percentage reported as inhibition, at one concentration (the size of the read-out at that concentration, not a potency): 26%
Compound 4: middle estimate off by 6 percentage points, on the low side; measured number inside the range.
By their numbers in this assay, from the lowest: compound 2; then compound 4; then compounds 1 and 3 (each within the scatter of the next).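

In this assay, for the compounds shown here, changing phenyl to 4-fluorophenyl gives a number 13 percentage points higher from compound 2 to compound 4 (beyond the scatter), so this place on the phenyl, para to a large group, responds to a single fluoro, something no earlier single-place step could show. Swapping hydrogen for fluoro on the core gave a number 76.2 percentage points lower from compound 1 to compound 2 (beyond the scatter), a much larger step in the opposite direction, so across these two pairs the same kind of swap has a different outcome depending on where it is made. No measurement at hand gives a reason for either step.

Going by these compounds, whether an amine or a methoxy group at this same place on the phenyl would move the number further remains open. Also open, on these data alone, is whether changing phenyl to 4-fluorophenyl on the core of compound 1 would give a step of similar size.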